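Chloro in place of nitro: what to expect

The compounds below may be only part of what the source reports. "The series", "measured", "known", "first", "only" and "open" are said of these compounds alone.

- compound 1 `COc1ccccc1/C=C/c1nc(Nc2cccc(O)c2)c2ccccc2n1` gives 16400 nM
- compound 2 `O=[N+]([O-])c1cccc(/C=C/c2nc(Nc3cccc(O)c3)c3ccccc3n2)c1` gives 10800 nM

In a functional assay on HCT-116 cells (Homo sapiens) for antiproliferative activity, with a stated time of 72 h (on this read-out lower numbers stand for stronger inhibition and higher numbers for weaker inhibition), compound 2 gives 10800 nM, within the scatter of compound 1. The unmeasured compound 3 `Oc1cccc(Nc2nc(/C=C/c3cccc(Cl)c3)nc3ccccc23)c1` carries chloro in place of nitro on an aromatic carbon, meta to a large group (chloro in place of nitro on an aromatic carbon). Among the measured compounds shown here, the one measured step bearing on this, a 1.5-fold lower number from compound 1 to compound 2 (0.18 log units; within the scatter), put 3-nitrophenyl in place of 2-methoxyphenyl. That exchange stayed within the scatter, so no step beyond the scatter is expected in this assay here. The expected change is a 1.1-fold lower number from compound 2 to compound 3 (0.03 log units; within the scatter) for this swap. Compound 3 is estimated at 10000 nM, with a range of 4000 nM to 25000 nM expected.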

Compound 3, half-maximal inhibitory concentration: > 25000 nM
Compound 3: only a limit was reported; the forecaster's own chance of this, stated with the estimate: 10%; middle value at least 2.5-fold (0.39 log units) from the limit.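

Unlike the earlier step, replacing nitro with chloro at this ring position moves the result beyond the scatter: an at least 2.3-fold higher number from compound 2 to compound 3 (0.36 log units; beyond the scatter). Set against 2-methoxyphenyl, 3-chlorophenyl gives an at least 1.5-fold higher number from compound 1 to compound 3 (0.18 log units; that floor lies within the scatter), so this floor alone does not separate the two groups. The result for compound 3 in this assay is only a limit, not a number: the limit of > 25000 nM in this assay, at which 1 of the 3 values shown sits.

As far as these compounds go, how far compound 3 truly lies from the others stays open. So does whether an amine or a carboxylic acid at this position would give a lower number than nitro.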